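From diethylamino to methoxycarbonyl on the shared core

The source may hold more compounds than are shown below. What is called first, only, known or untested is meant among the compounds shown, and "the series" means these compounds.

Measured so far in a functional assay on the whole organism with Rattus norvegicus as the target (a lower number here means that less compound is needed, a higher number that more compound is needed for the effect), are three compounds
Compound 1 (`CCOC(=O)C(=O)Nc1cccc(N)c1C#N`) gives 0.07 mg/kg
Compound 2 (`CCOC(=O)C(=O)Nc1cccc(N(C)CC)c1C#N`) gives 0.5 mg/kg
Compound 3 (`CCOC(=O)C(=O)Nc1cccc(N(CC)CC)c1C#N`) gives 0.9 mg/kg

Compound 3 cannot be told apart from compound 2 on these numbers, since a 1.8-fold higher number from compound 2 to compound 3 (0.26 log units; within the scatter) lies within the scatter. Both stand well above compound 1, with a 7.1-fold higher number from compound 1 to compound 2 (0.85 log units; beyond the scatter) and a 13-fold higher number from compound 1 to compound 3 (1.11 log units; beyond the scatter) as the measured gaps.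

Compound 4 (`CCOC(=O)C(=O)Nc1cccc(C(=O)OC)c1C#N`) has not yet been measured. It carries methoxycarbonyl in place of diethylamino on an aromatic carbon, ortho to a cyano group (methoxycarbonyl in place of diethylamino on an aromatic carbon) and so no longer has a nitrogen on that carbon.

The three measured steps bear on this change only loosely. They show that compound 2 and compound 3, with alkyl groups on the nitrogen, both give higher numbers than compound 1, but every measured compound keeps a nitrogen at this carbon. The data therefore say little about methoxycarbonyl itself. Nothing points firmly in either direction, so no step beyond the scatter is expected, and the uncertainty is wide. The estimated change is a 1.5-fold lower number from compound 3 to compound 4 (0.18 log units; within the scatter) in this assay on this reasoning. Compound 4 is expected at 0.6 mg/kg with an estimated range from 0.1 mg/kg to 3 mg/kg for the measurement.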

Compound 4, dose for half-maximal effect: 0.8 mg/kg
Compound 4: middle estimate off by 1.3-fold (0.12 log units), on the low side; measured number inside the range.
By their numbers in this assay, from the lowest: compound 1; then compounds 2, 4 and 3 (each within the scatter of the next).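

In this assay, the change to methoxycarbonyl removes the nitrogen from this aromatic carbon, yet it gives a 1.1-fold lower number from compound 3 to compound 4 (0.05 log units; within the scatter) and so leaves compound 4 level with the diethylamino compound. The comparison with the ethyl(methyl)amino compound reads the same way, with a 1.6-fold higher number from compound 2 to compound 4 (0.20 log units; within the scatter) as the step, so the earlier link between the alkylated nitrogen and the higher numbers does not extend to a need for nitrogen at this carbon: a group with no nitrogen at all sits in the same range. The amino compound alone stands apart among these four, with an 11-fold higher number from compound 1 to compound 4 (1.06 log units; beyond the scatter) as the step, which sets it off from methoxycarbonyl as clearly as from the two alkylated amines.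

Going by these compounds, whether the low number of compound 1 belongs to amino specifically stays open, since methylamino, hydroxyl or plain hydrogen on this carbon, or a carboxylic acid in place of the methyl ester, could each separate what the shared range of compounds 2, 3 and 4 cannot. Nothing measured here offers an explanation for why such different groups give such similar numbers in this assay.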